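A few compounds are considered here, and "the series" means these few. Any claim that something is new, unique, unknown or untested is made for them only; others in the source may bear on it.

The series is tested in a functional assay on UACC-62 cells (Homo sapiens) for inhibition, read by sulforhodamine B assay, with a stated time of 48 h; a lower number here means that less compound is tolerated, a higher number that more compound is tolerated. Compound 1, `O=C(Nc1cccc(-n2cc(-c3ccncc3)c(-c3ccc(Cl)c(O)c3)n2)c1)Nc1ccc(Cl)c(Cl)c1`, gives 29200 nM in this assay. Compound 2, `COc1cc(-c2nn(-c3cccc(NC(=O)c4cccc(C(F)(F)F)c4)c3)cc2-c2ccncc2)ccc1Cl`, reaches only a limit of the assay, reported as > 50000 nM in this assay. That limit, (the limit of > 50000 nM in this assay, at which 1 of the 2 values shown sits), means that for compound 2 only a bound is known and no number. Compound 3, `COc1cc(-c2nn(-c3cccc(NC(=O)c4ccccc4)c3)cc2-c2ccncc2)ccc1Cl`, has not yet been measured in this assay. It differs from compound 2 in one place: hydrogen in place of trifluoromethyl on an aromatic carbon. Within the data shown here, no measured step in this assay bounds such a change, and the one measured point of compound 2 is itself a limit. The step expected here, an at least 1.1-fold lower number from compound 2 to compound 3 (0.04 log units; that floor lies within the scatter), is small, with no shift beyond the scatter foreseen in either direction. Compound 3 is therefore estimated at 45000 nM in this assay, within a range from 15000 nM to 100000 nM, and with a fair chance that the assay once more reports only a limit.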

Compound 3, concentration lethal to 50% of the cells: > 100000 nM
Compound 3: only a limit was reported (the forecaster's own chance of this, stated with the estimate: 55%); middle value at least 2.2-fold (0.34 log units) from the limit.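

In this assay compound 3 gives > 100000 nM, which is a limit. Compound 2 gives > 50000 nM, also a limit, so no step can be read between compound 2 and compound 3. The compounds shown leave open what hydrogen in place of trifluoromethyl does to the number, in size or in direction.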